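The source may hold more compounds than are shown below. What is called first, only, known or untested is meant among the compounds shown, and "the series" means these compounds.

Measured in a functional assay on HCT-116 cells (Homo sapiens) for antiproliferative activity, read by MTT assay, with a stated time of 72 h; on this read-out higher numbers stand for weaker inhibition and lower numbers for stronger inhibition:
- compound 1 `Nc1nc(N)c2cc(CSC(=S)N3CCN(c4ccc(Cl)cc4)CC3)ccc2n1`: 7380 nM
- compound 2 `Nc1nc(N)c2cc(CSC(=S)N3CCN(c4ccc(F)cc4F)CC3)ccc2n1`: 5150 nM

Within the data shown here, compound 2, at 5150 nM, cannot be told apart from compound 1 on these numbers, as the only measured step is a 1.4-fold lower number from compound 1 to compound 2 (0.16 log units; within the scatter). The series therefore has no clear ranking so far.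

The next compound is compound 3 `Nc1nc(N)c2cc(CSC(=S)N3CCN(c4ncccn4)CC3)ccc2n1`, which carries pyrimidin-2-yl in place of 2,4-difluorophenyl on an amine nitrogen in a ring.

Among the measured compounds shown here, the single measured step bears on this change, since it also exchanged one aromatic group at that same place, and it stayed within the scatter. It is only a weak guide, however. For the measured compounds named here, it joined two rings of carbon only, whereas compound 3 brings a ring with hetero atoms, and no measured step covers such a swap. The data set no direction, so no step beyond the scatter is expected, with wide margins on either side.

The estimated change is a 1.2-fold higher number from compound 2 to compound 3 (0.07 log units; within the scatter). For compound 3 the expected value is 6000 nM, with an estimated range of 2500 nM to 15000 nM.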

Compound 3, half-maximal inhibitory concentration: 5840 nM
The estimate for compound 3 lay 1.0-fold (0.01 log units) above the measured number; the measured number falls inside the stated range.
By their numbers in this assay, from the lowest: compounds 2, 3 and 1 (each within the scatter of the next).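

In this assay, putting a ring with hetero atoms in place of a ring of carbon only, on an amine nitrogen in a ring, gave a 1.1-fold higher number from compound 2 to compound 3 (0.05 log units; within the scatter), and the same group set against the 4-chlorophenyl of compound 1 gave a 1.3-fold lower number from compound 1 to compound 3 (0.10 log units; within the scatter). Pyrimidin-2-yl, with 2 hydrogen-bond acceptors where 2,4-difluorophenyl has 0, thus stays within the scatter of both earlier compounds, so among these three compounds the flat picture at this place now reaches beyond rings of carbon only. Nothing measured beyond these numbers accounts for the lack of separation.

As far as these compounds go, it remains open whether a group of another kind at this place, such as a methyl group, a longer alkyl chain, or an aromatic ring carrying an amine or a carboxylic acid, would move the number beyond the scatter. It is also open whether changes elsewhere on the shared core would separate compounds more clearly than the three aromatic rings shown here.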